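From 3,5-difluorophenyl to pyridin-3-yl on a shared core

A few compounds are considered here, and "the series" means these few. Any claim that something is new, unique, unknown or untested is made for them only; others in the source may bear on it.

Of the compounds shown here, three have been measured in a functional assay on A-375 cells (Homo sapiens) for activation, with a stated time of 3 days; a higher number here means that more compound is needed for the effect, a lower number that less compound is needed. Compound 1 `O=C(Nc1ccc2scnc2c1)C1CCCN(Cc2ccc(F)c(F)c2)C1` gives > 20000 nM, which is a limit of the assay and not a number. Compound 2 `O=C(Nc1ccc(-c2cscn2)cc1)[C@H]1CCCN(Cc2ccc(F)c(F)c2)C1` gives 270 nM. Compound 3 `O=C(Nc1ccc(-c2cscn2)cc1)C1CCCN(Cc2cc(F)cc(F)c2)C1` gives 1500 nM, the higher of the two actual numbers, and its gap to compound 2 lies beyond the usual scatter. More of compound 3 is therefore needed for the same effect.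

Compound 4 `O=C(Nc1ccc(-c2cscn2)cc1)C1CCCN(Cc2cccnc2)C1` has pyridin-3-yl in place of 3,5-difluorophenyl on a saturated chain carbon bound to an amine nitrogen in a ring. Among the compounds with values here, no measured pair shows this exchange, so the expectation rests on the structural change alone and is uncertain. A moderate move towards a higher number in this assay seems likely, and the estimated step is a 3.0-fold higher number from compound 3 to compound 4 (0.48 log units; beyond the scatter). Compound 4 is expected at about 4500 nM, with an estimated range of 1200 nM to 17000 nM.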

Compound 4, half-maximal effective concentration: > 20000 nM
Compound 4: a limit, no number; the forecaster's own chance of this, stated with the estimate: 20%; middle value at least 4.4-fold (0.64 log units) from the limit.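

Putting pyridin-3-yl in place of 3,5-difluorophenyl on a saturated chain carbon bound to an amine nitrogen in a ring gives an at least 13-fold higher number from compound 3 to compound 4 (1.12 log units; beyond the scatter), a large loss in this assay. Within the data shown here, this is the first exchange measured at this place, and it shows that the outcome there depends strongly on which ring is attached. Compound 4 gives > 20000 nM, which is a limit of the assay and not a number, so the full size of the step remains unknown: the limit of > 20000 nM in this assay, at which 2 of the 4 values shown sit.

The exchange removes both fluorines and brings a ring nitrogen at once, so the compounds shown cannot tell which of these two changes matters. A plain phenyl ring would separate them, and 5-fluoropyridin-3-yl would show whether a fluorine restores activity alongside the ring nitrogen.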